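This account rests on a few compounds, and the source may have more. Where it says the series, first, only, none or still open, it means among the compounds named here.

Compound 1 `CCOc1nc(C(C)(C)C)ccc1CNC(=O)C(C)c1ccc(NS(C)(=O)=O)c(F)c1` is the starting point of this account. For the measured compounds named here, in an assay on cells for antagonist activity at transient receptor potential cation channel subfamily V member 1 (Homo sapiens), read by FLIPR and calcium flux, with a stated time of 6 min (on this read-out lower numbers stand for stronger inhibition and higher numbers for weaker inhibition), compound 1 gives 14.8 nM, the highest of the three numbers measured so far. Compound 2 `CCCCCCOc1nc(C(C)(C)C)ccc1CNC(=O)C(C)c1ccc(NS(C)(=O)=O)c(F)c1` gives 2.7 nM in this assay, and compound 3 `CCCCSc1nc(C(C)(C)C)ccc1CNC(=O)C(C)c1ccc(NS(C)(=O)=O)c(F)c1` gives 3.2 nM. Two steps lead away from compound 1: a 5.5-fold lower number from compound 1 to compound 2 (0.74 log units; beyond the scatter), and a 4.6-fold lower number from compound 1 to compound 3 (0.67 log units; beyond the scatter). Between the two larger groups there is a 1.2-fold higher number from compound 2 to compound 3 (0.07 log units; within the scatter), so both enlargements end in much the same place.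

Compound 4 `COc1ccc(CSc2nc(C(C)(C)C)ccc2CNC(=O)C(C)c2ccc(NS(C)(=O)=O)c(F)c2)cc1` has not yet been measured in this assay. It differs from compound 1 by (4-methoxybenzyl)sulfanyl in place of ethoxy on an aromatic carbon. Both measured steps from compound 1 bear on it. Each replaced the ethoxy with a larger group, and each lowered the number: a 5.5-fold lower number from compound 1 to compound 2 (0.74 log units; beyond the scatter), and a 4.6-fold lower number from compound 1 to compound 3 (0.67 log units; beyond the scatter). The group entering here is larger again and is a sulfanyl like that of compound 3. He therefore expects a lowering of about a 3.7-fold lower number from compound 1 to compound 4 (0.57 log units; beyond the scatter). His estimate for compound 4 is 4 nM, with a range from 1.3 nM to 12 nM.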

Compound 4, inhibition constant: 3.5 nM
Beside the measured number, compound 4's estimate is 1.1-fold (0.06 log units) above it, and the stated range covers the measured number.
By their numbers in this assay, from the lowest: compounds 2, 3 and 4 (each within the scatter of the next); then compound 1.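

The (4-methoxybenzyl)sulfanyl group brings a six-membered aromatic ring of carbon only to this position, and in this assay the number still falls (a 4.2-fold lower number from compound 1 to compound 4 (0.63 log units; beyond the scatter)), so the gain seen with the open chains of compound 2 and compound 3 also holds for a group bearing a ring. The ring and its methoxy group give no separation from either chain, as both remaining steps lie within the scatter (a 1.1-fold higher number from compound 3 to compound 4 (0.04 log units; within the scatter); a 1.3-fold higher number from compound 2 to compound 4 (0.11 log units; within the scatter)). Nothing available accounts for these three larger groups arriving at the same level.

On these data alone, it remains open whether an amine or a carboxylic acid at the end of this group would hold the number at that level. Also open, as far as these compounds go, is how a butoxy group compares with butylsulfanyl, and whether a chain longer than hexyloxy would keep the same level.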